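The source may report more compounds than this note shows. Statements on the series, on what has been measured and on what is new or still open speak of the compounds shown alone.

Four compounds share one core. Compound 1 `CC(O)(CSc1ccc(C(F)(F)F)cc1)C(=O)Nc1ccc(S(F)(F)(F)(F)F)cc1` and compound 2 `CC(O)(CSc1ccc(OC(F)(F)F)cc1)C(=O)Nc1ccc(S(F)(F)(F)(F)F)cc1` carry their groups in one arrangement, while compound 3 `CC(O)(CSc1cccc(C(F)(F)F)c1)C(=O)Nc1cccc(S(F)(F)(F)(F)F)c1` and compound 4 `CC(O)(CSc1cccc(OC(F)(F)F)c1)C(=O)Nc1cccc(S(F)(F)(F)(F)F)c1` contain the same atoms joined differently; the difference between the two cores is not broken down here. In a functional assay on DU-145 cells (Homo sapiens) for antiproliferative activity, read by propidium iodide staining, with a stated time of 96 h (a higher number here means a weaker inhibitor, a lower number a stronger inhibitor), compound 1 gives 28800 nM, compound 2 gives 12500 nM, and compound 3 gives 19100 nM. The change from compound 1 to compound 2 is trifluoromethoxy in place of trifluoromethyl on an aromatic carbon and it brought a 2.3-fold lower number from compound 1 to compound 2 (0.36 log units; beyond the scatter). The change from compound 3 to compound 4 is trifluoromethoxy in place of trifluoromethyl on an aromatic carbon. This is the same kind of change, though not the same: in the earlier pair the group stands para to a large group, here it stands meta to a large group, so the surroundings of the place differ. A step of roughly the earlier size is expected, a 2.2-fold lower number from compound 3 to compound 4 (0.35 log units; beyond the scatter), because the same kind of change brought a 2.3-fold lower number from compound 1 to compound 2 (0.36 log units; beyond the scatter). Compound 4 is therefore estimated at 8500 nM, with a likely range from 4000 nM to 18000 nM.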

Compound 4, half-maximal inhibitory concentration: 25000 nM
Compound 4: middle estimate off by 2.9-fold (0.47 log units), on the low side, and the stated range ends below it.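

In this assay, putting trifluoromethoxy in place of trifluoromethyl gave a 1.3-fold higher number from compound 3 to compound 4 (0.12 log units; within the scatter), so on this core the swap produced no change that stands clear of the usual scatter. The gain seen on the core of compound 1 therefore did not carry over to the core of compound 3, and the two results truly differ: the same change on two cores in this assay, a 2.3-fold lower number (0.36 log units; beyond the scatter) from compound 1 to compound 2 and a 1.3-fold higher number (0.12 log units; within the scatter) from compound 3 to compound 4, 3.0-fold (0.48 log units) apart, beyond the scatter of two such steps This shows that a step measured on one of these cores cannot simply be assumed on the other, but with a single pair on each core it does not set a general rule, and it does not show which part of the difference between the cores matters.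

The compounds shown leave open how other groups in the same place, such as a methoxy group, a chlorine atom or a nitrile, would behave on the two cores. They also leave open whether the step would hold on a core that differs from the core of compound 1 in only one place.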